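Toxicity of Enamine Pyrone Indazoles in Macrophage Cells

The compounds below may be only part of what the source reports. "The series", "measured", "known", "first", "only" and "open" are said of these compounds alone.

Measured compounds:
compound 1, `CC1=CC(=O)/C(=C(/C)Nc2ccc3c(Cl)nn(Cc4ccc(C)cc4)c3c2)C(=O)O1`, > 100000 nM
compound 2, `CCn1nc2cc(N/C(C)=C3\C(=O)C=C(C)OC3=O)ccc2c1Cl`, 6250 nM
compound 3, `CC1=CC(=O)/C(=C(/C)Nc2ccc3nn(C)cc3c2)C(=O)O1`, > 100000 nM

Of the compounds shown here, three have been tested in an ADME assay on RAW264.7 cells (Mus musculus) for cytotoxicity, read by resazurin assay, with a stated time of 48 h; on this read-out higher numbers stand for lower toxicity in this test and lower numbers for higher toxicity in this test. For compound 1 the result is a limit of the assay, > 100000 nM. For compound 3 the result is likewise only a limit, > 100000 nM. Among the compounds with values here, compound 2 gives a number, 6250 nM, and stands alone as the one measurable value. Compound 3 therefore sits at the limit of > 100000 nM in this assay, at which 2 of the 3 values shown sit, so its true value is not known, only that it lies past that bound.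

Compound 4, `CCn1cc2cc(N/C(C)=C3\C(=O)C=C(C)OC3=O)ccc2n1`, is not yet measured. It differs from compound 3 in one place: methyl in place of hydrogen on a saturated chain carbon bound to an aromatic nitrogen. Within the data shown here, compound 2 carries the same ethyl chain, and compound 2 is the one measured compound with a number, but compound 2 differs from compound 4 in other places too, so no step can be taken from it. Because compound 3 sits at the limit of > 100000 nM in this assay, at which 2 of the 3 values shown sit, the step from compound 3 to compound 4 cannot be measured against a number; the expectation is a step of an at least 1.6-fold lower number from compound 3 to compound 4 (0.22 log units; that floor lies within the scatter), toward somewhat higher toxicity. Compound 4 is estimated at 60000 nM, between 15000 nM and 200000 nM.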

Compound 4, half-maximal cytotoxic concentration: > 100000 nM
Compound 4 gave a limit, no number (the forecaster's own chance of this, stated with the estimate: 40%); middle value at least 1.6-fold (0.22 log units) away from the limit.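

Compound 3 and compound 4 each give only a limit in this assay, so no step can be read between them: the limit of > 100000 nM in this assay, at which 3 of the 4 values shown sit.

The compounds shown leave open whether methyl in place of hydrogen on a saturated chain carbon bound to an aromatic nitrogen changes toxicity in this test at all.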